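A few compounds are considered here, and "the series" means these few. Any claim that something is new, unique, unknown or untested is made for them only; others in the source may bear on it.

Measured compounds:
compound 1, `COC(=O)c1ccc2ccc(C(=O)c3ccc(C(F)(F)F)cc3)c-2cc1` — in an assay on cells for displacement of a labelled ligand from Orexin receptor type 2 (Homo sapiens), read by scintillation counting, with stated times of 10 min and 90 min, tested at 10 uM (a lower number here means less inhibition, a higher number more inhibition at the concentration tested (going by the name of the read-out)), compound 1 gives -47.4%
compound 2, `O=C(O)c1ccc2ccc(C(=O)c3ccc(C(F)(F)F)cc3)c-2cc1` — compound 2 gives 1%
compound 3, `COC(=O)c1cccc2c(C(=O)c3ccccc3)cc(C(=O)c3ccc(C(F)(F)F)cc3)c-2c1` — compound 3 gives 27%

Compound 3 stands highest of the three numbers in this assay. Its nearest neighbour is compound 2, whose value lies beyond the scatter below it, and compound 1 lies furthest below, also beyond the scatter. Among the measured compounds shown here, the only single-place step among the measured compounds is a number 48.4 percentage points higher from compound 1 to compound 2 (beyond the scatter), a large rise that comes from hydrogen in place of methyl on an oxygen next to a carbonyl group.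

Compound 4, `COC(=O)c1cccc2c(C(=O)c3ccccc3)cc(C(=O)c3ccc(C(Cl)(Cl)Cl)cc3)c-2c1`, is reached from compound 3 by trichloromethyl in place of trifluoromethyl on an aromatic carbon. No measured step touches this part of the structure: the step from compound 1 to compound 2 concerns the ester, not the trifluoromethyl, and compound 3 carries both a methyl ester and a benzoyl that compound 1 and compound 2 lack, so no listed comparison bears on the exchange of trifluoromethyl for trichloromethyl. The expectation therefore rests on compound 3 alone, and the estimated step is a number 2 percentage points lower from compound 3 to compound 4 (within the scatter), within the scatter. In this assay compound 4 is estimated at 25%, expected to fall between 0% and 50%.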

Compound 4, a percentage reported as inhibition, at one concentration (the size of the read-out at that concentration, not a potency): 27%
Compound 4: middle estimate off by 2 percentage points, on the low side; measured number inside the range.
By their numbers in this assay, from the lowest: compound 1; then compound 2; then compounds 3 and 4 (each within the scatter of the next).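

Among the compounds shown here, exchanging trifluoromethyl for trichloromethyl on an aromatic carbon, para to a large group, gives in this assay no change at the digits printed from compound 3 to compound 4 (within the scatter), the first measured change at this position, since the only earlier single-place step, a number 48.4 percentage points higher from compound 1 to compound 2 (beyond the scatter), concerned the ester. With the rest of the structure held constant, this assay at this one concentration therefore does not separate 4-(trifluoromethyl)phenyl from 4-(trichloromethyl)phenyl, a finding that holds for this single pair and for no wider set of groups. Nothing among the available data explains why the two groups read alike.

The compounds shown leave open whether a group of another kind at this same place, such as a nitrile, an amine, a carboxylic acid or a plain methyl, would move the number beyond the scatter, or whether the position would accept these as well. They also leave open whether trichloromethyl would read the same on the core of compound 1, which has no benzoyl, and whether hydrogen in place of methyl on the ester oxygen would produce a comparable rise on compound 3 or compound 4.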